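Varying the Aryl Group on the Ring Amide Nitrogen

The compounds below may be only part of what the source reports. "The series", "measured", "known", "first", "only" and "open" are said of these compounds alone.

Of the compounds shown here, three sharing one core have been measured in a functional assay on HEK293 cells for positive allosteric modulation of metabotropic glutamate receptor 5 (Homo sapiens), read by calcium flux; a higher number here means a larger maximal response, a lower number a smaller maximal response. Compound 1 `O=C1c2cc(COc3ccccc3)nn2CCN1c1cccc(F)c1` gives 81% in this assay. Compound 2 `O=C1c2cc(COc3ccccc3)nn2CCN1c1ccc(F)cc1F` gives 101%, and compound 3 `COc1ccc(N2CCn3nc(COc4ccccc4)cc3C2=O)nc1` gives 74%. Compound 3 thus stands lowest of the three numbers: its nearest neighbour is compound 1, with the step of a number 7 percentage points lower from compound 1 to compound 3 (within the scatter) lying within the scatter, while its furthest is compound 2, with a number 27 percentage points lower from compound 2 to compound 3 (beyond the scatter) lying beyond it. The remaining step, a number 20 percentage points higher from compound 1 to compound 2 (beyond the scatter), is also beyond the scatter.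

The next compound, compound 4 `O=C1c2cc(COc3ccccc3)nn2CCN1c1ncc(F)cn1`, differs from compound 3 in one place: 5-fluoropyrimidin-2-yl in place of 5-methoxypyridin-2-yl on an amide-type nitrogen in a ring. The two steps that bear on this change are those that replace the group on the same amide-type nitrogen in a ring, namely a number 7 percentage points lower from compound 1 to compound 3 (within the scatter) and a number 27 percentage points lower from compound 2 to compound 3 (beyond the scatter); they show that such exchanges move the maximal response in this assay by modest amounts at most, and none of them involves the 5-fluoropyrimidin-2-yl group itself. For compound 4 a step of a number 4 percentage points higher from compound 3 to compound 4 (within the scatter) is therefore expected, a change not beyond the scatter. The estimate for compound 4 in this assay is 78%, with a range from 60% to 100%.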

Compound 4, largest response reached (Emax), in percent of the reference or control that the assay uses: 72%
The estimate for compound 4 lay 6 percentage points above the measured number, and the stated range covers the measured number.
By their numbers in this assay, from the lowest: compounds 4, 3 and 1 (each within the scatter of the next); then compound 2.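

Placing the 5-fluoropyrimidin-2-yl group on the amide-type nitrogen in the ring extends the range of aromatic rings tested at this position to one with 2 hetero atoms, and in this assay this exchange gives a number 2 percentage points lower from compound 3 to compound 4 (within the scatter), while replacing the 3-fluorophenyl group gives a number 9 percentage points lower from compound 1 to compound 4 (within the scatter), so compounds 1, 3 and 4 form a group whose rings carry no, 1 or 2 hetero atoms. The number of hetero atoms in the ring therefore does not separate these three compounds, and the one clear departure is the 2,4-difluorophenyl group of compound 2, with the exchange for the 5-fluoropyrimidin-2-yl group giving a number 29 percentage points lower from compound 2 to compound 4 (beyond the scatter), although compound 1 shows that a fluorinated phenyl ring alone does not produce this higher response. Nothing available here gives a reason for the separate position of compound 2.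

From the compounds shown here alone, whether a 2-fluorophenyl or a 4-fluorophenyl group on this nitrogen would match compound 2 or stay with the other three remains open. So does the response with a 2,4-dichlorophenyl group, or with a cyclohexyl ring in place of the aromatic ring at this position.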